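Methyl for oxolan-2-yl on compound 1

The source may report more compounds than this note shows. Statements on the series, on what has been measured and on what is new or still open speak of the compounds shown alone.

Among the measured compounds shown here, in a physicochemical assay for lipophilicity, at pH 7.4 (on this read-out higher numbers stand for higher lipophilicity and lower numbers for lower lipophilicity), compound 1 (`Cc1cc(C)c(CN2CCc3c(Cl)cc([C@H](CO)[C@H]4CCCO4)c(Cl)c3C2=O)c(=O)[nH]1`) gives 2.1 as its only single number, and two further entries give none. Compound 3 (`Cc1cc(C)c(CN2CCc3c(Cl)cc(C(CO)C4CCOC4)c(Cl)c3C2=O)c(=O)[nH]1`) gives 2.1; 2.1 (2 entries) and compound 2 (`COC(c1cc(Cl)c2c(c1Cl)C(=O)N(Cc1c(C)cc(C)[nH]c1=O)CC2)C1CCS(=O)(=O)CC1`) gives 2.2; 2.2 (2 entries) in the same measurement, so all three lie within the scatter of one another. Compound 4 (`Cc1cc(C)c(CN2CCc3c(Cl)cc([C@@H](C)CO)c(Cl)c3C2=O)c(=O)[nH]1`) is still unmeasured. It carries methyl in place of oxolan-2-yl (methyl in place of oxolan-2-yl on a saturated chain carbon bound to an aromatic carbon and a saturated chain carbon) on a saturated chain carbon bound to an aromatic carbon and a saturated chain carbon. For the measured compounds named here, no measured pair isolates this change. Since compound 2 at 2.2; 2.2 (2 entries) and compound 3 at 2.1; 2.1 (2 entries) bear other groups yet read alike, no step beyond the scatter is expected in this assay in either direction. The estimated step of a number 0.10 log units higher from compound 1 to compound 4 (within the scatter) stays within that scatter. In this assay compound 4 is estimated at 2.2 with a range from 1.8 to 2.6 expected.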

Compound 4, distribution coefficient: 2.5
The estimate for compound 4 lay 0.30 log units below the measured number; the measured number falls inside the stated range.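

In this assay, methyl in place of oxolan-2-yl on a saturated chain carbon bound to an aromatic carbon and a saturated chain carbon gives a number 0.40 log units higher from compound 1 to compound 4 (beyond the scatter). Among the compounds shown here, this is the first pair differing in one place, and it shows that the read-out responds to a change at this position. Nothing measured here accounts for the step.

This single pair does not separate the loss of the ring from the loss of its oxygen. Where a cyclopentyl or ethyl group would fall at this place remains open.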